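Fluoro for chloro on the sulfonyl side of compound 3

The compounds below may be only part of what the source reports. "The series", "measured", "known", "first", "only" and "open" are said of these compounds alone.

The series rests on one shared core carried by compound 1 `N#C/C(=C\c1ccccc1OS(=O)(=O)c1ccccc1[N+](=O)[O-])C(=O)Nc1nnc(Cc2ccc(F)cc2)s1`, compound 2 `N#C/C(=C\c1ccccc1OS(=O)(=O)c1ccccc1[N+](=O)[O-])C(=O)Nc1nnc(Cc2ccc(Cl)cc2)s1` and compound 3 `N#C/C(=C\c1ccccc1OS(=O)(=O)c1ccc(Cl)cc1)C(=O)Nc1nnc(Cc2ccc(Cl)cc2)s1`. In a functional assay on HL-60 cells (Homo sapiens) for inhibition, read by CCK-8 assay, with a stated time of 48 h, tested at 20 uM (on this read-out higher numbers stand for more inhibition of growth at the one concentration tested and lower numbers for less inhibition of growth), compound 1 gives 35%, compound 2 gives 19% and compound 3 gives 15%. Compound 2 differs from compound 1 by fluoro in place of chloro on an aromatic carbon, and this change gave a number 16 percentage points higher from compound 2 to compound 1 (beyond the scatter). Compound 3 differs from compound 2 by 4-chlorophenyl in place of 2-nitrophenyl on a sulfonyl sulfur, which gave a number 4 percentage points lower from compound 2 to compound 3 (within the scatter).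

Compound 4 `N#C/C(=C\c1ccccc1OS(=O)(=O)c1ccc(F)cc1)C(=O)Nc1nnc(Cc2ccc(Cl)cc2)s1` has not been measured in this assay. It differs from compound 3 by fluoro in place of chloro on an aromatic carbon, the same change as between compound 2 and compound 1, though cut one bond further out it reads (4-chlorophenyl)sulfonyl to (4-fluorophenyl)sulfonyl rather than 4-chlorobenzyl to 4-fluorobenzyl. Among the compounds with values here, because only one example of this change, a number 16 percentage points higher from compound 2 to compound 1 (beyond the scatter), is known, and on another part of the molecule, the author expects a smaller step, a number 8 percentage points higher from compound 3 to compound 4 (within the scatter), for compound 4. Compound 4 is accordingly estimated at 23%, between 10% and 40%.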

Compound 4, percent growth inhibition at one concentration: 20%
Compound 4: the middle estimate sits 3 percentage points above what was measured, within the range that was stated.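

In this assay, fluoro in place of chloro on the (4-chlorophenyl)sulfonyl group gave a number 5 percentage points higher from compound 3 to compound 4 (within the scatter), and the two steps for this change do not differ by more than repeated measurements allow: the same change on two cores in this assay, a number 16 percentage points higher (beyond the scatter) from compound 2 to compound 1 and a number 5 percentage points higher (within the scatter) from compound 3 to compound 4, 11 percentage points apart, within the scatter of two such steps. Within the data shown here, the data therefore give no sign that the change behaves differently on the two cores, but they do not show that it carries over with a set size, as only two pairs are available and only the step on the 4-chlorobenzyl group lies beyond the scatter. Exchanging 2-nitrophenyl for 4-fluorophenyl on the sulfonyl sulfur gave a number 1 percentage points higher from compound 2 to compound 4 (within the scatter), so this pair does not separate the two groups on this read-out.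

The compounds shown leave open whether a quite different group on the sulfonyl sulfur, such as a small alkyl chain or an aminophenyl group, would shift growth inhibition beyond the scatter. They also leave open what fluoro does when it is carried on both halves of the molecule at once.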